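The compounds below may be only part of what the source reports. "The series", "measured", "known", "first", "only" and "open" are said of these compounds alone.

Measured compounds in a functional assay on DU-145 cells (Homo sapiens) for inhibition, read by trypan blue exclusion, with a stated time of 96 h; on this read-out higher numbers stand for weaker inhibition of growth and lower numbers for stronger inhibition of growth:

compound 1 `O=C(/C(=C\c1ccccc1OCc1ccccc1)SCc1ccc(Cl)c(Cl)c1)c1ccc(Cl)cc1`: compound 1 gives 10000 nM.
compound 2 `COc1ccccc1/C=C(/SCc1ccc(Cl)c(Cl)c1)C(=O)c1ccc(Cl)cc1`: compound 2 gives 10000 nM.
compound 3 `O=C(/C(=C\c1ccc(Br)cc1)S(=O)(=O)Cc1ccc(F)cc1)c1ccc(Cl)cc1`: compound 3 gives > 100000 nM, which is a limit of the assay and not a number.

Compound 1 stands level with compound 2 at the digits given. Among the measured compounds shown here, the only single-point step measured, no change at the digits printed from compound 1 to compound 2 (within the scatter), lies within the scatter, so the change of hydrogen in place of phenyl on a saturated chain carbon bound to an oxygen on an aromatic ring leaves the growth inhibition where it was. For the measured compounds named here, compound 3 sits at the limit of > 100000 nM in this assay, at which 1 of the 3 values shown sits; it differs from compound 1 in more than one place, so no step to it is available, and only its limit can be stated.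

Compound 4 `Cc1ccc(CS/C(=C/c2ccccc2OCc2ccccc2)C(=O)c2ccc(Cl)cc2)cc1` differs from compound 1 by 4-methylphenyl in place of 3,4-dichlorophenyl on a saturated chain carbon bound to a sulfur. Going by the values given here, no measured step touches a saturated chain carbon bound to a sulfur, so the only guide is that the one step seen, from compound 1 to compound 2, moved nothing beyond the scatter. On that basis a step of a 1.5-fold higher number from compound 1 to compound 4 (0.18 log units; within the scatter) is expected, within the scatter, with slight lean toward weaker inhibition. Compound 4 is expected at 15000 nM, between 5000 nM and 60000 nM.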

Compound 4, concentration for 50% growth inhibition: 1000 nM
Estimate against measurement, compound 4: 15-fold (1.18 log units) above, outside the stated range (below it).
By their numbers in this assay, from the lowest: compound 4; then compounds 1 and 2 (each within the scatter of the next). At a limit, above all of these: compound 3.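

In this assay the change to 4-methylphenyl in place of 3,4-dichlorophenyl on a saturated chain carbon bound to a sulfur gives a 10-fold lower number from compound 1 to compound 4 (1.00 log units; beyond the scatter) and is the only step shown that clears the scatter. This place therefore responds to a single change in a way the other step shown, no change at the digits printed from compound 1 to compound 2 (within the scatter), did not, and in this pair the 3,4-dichlorophenyl group is not required for growth inhibition at the level of compound 4. No measurement shown gives a reason for this step.

As far as these compounds go, the step removes both chlorines and brings in the methyl at once, so it stays open whether losing chlorine or gaining methyl carries the change, and whether a 4-chlorophenyl or an unsubstituted phenyl group would read with compound 1 or with compound 4. Also open, from the compounds shown here alone, is how an amine or a carboxylic acid on this ring would read, and whether a longer chain in place of the saturated chain carbon bound to a sulfur would keep the level of compound 4.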